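Swapping the aryl group on the amide nitrogen

The source may hold more compounds than are shown below. What is called first, only, known or untested is meant among the compounds shown, and "the series" means these compounds.

Among the compounds with values here, compound 2 `COc1ccc(C(=O)Nc2ccccc2SC)cc1OC1CCCC1` is the only compound here with a numeric result in an assay on isolated protein for inhibition of phosphodiesterase 4A (Sus scrofa); a higher number here means a weaker inhibitor, a lower number a stronger inhibitor: compound 2 gives 1200 nM. Compound 1 `COc1ccc(C(=O)Nc2cccc(Cl)c2Cl)cc1OC1CCCC1` reaches only the assay limit of > 200000 nM in this assay. Within the data shown here, the one measured step, an at least 160-fold lower number from compound 1 to compound 2 (2.22 log units; beyond the scatter), shows that the aryl group on the amide nitrogen can swing potency strongly. Compound 3 `COc1ccc(C(=O)Nc2ccccn2)cc1OC1CCCC1` carries pyridin-2-yl in place of 2-(methylsulfanyl)phenyl on an amide-type nitrogen. Among the measured compounds shown here, no measured step matches this exact change, so the direction is uncertain; a modest loss is expected, a 2.5-fold higher number from compound 2 to compound 3 (0.40 log units; beyond the scatter). Compound 3 is estimated at 3000 nM, within 500 nM to 20000 nM.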

Compound 3, half-maximal inhibitory concentration: 1000 nM
Estimate against measurement, compound 3: 3.0-fold (0.48 log units) above; the range from low to high includes it.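

In this assay, pyridin-2-yl serves as well as 2-(methylsulfanyl)phenyl on the amide nitrogen, with a 1.2-fold lower number from compound 2 to compound 3 (0.08 log units; within the scatter), so the sulfur-bearing group is not required here. Measured against 2,3-dichlorophenyl, the same group gives an at least 200-fold lower number from compound 1 to compound 3 (2.30 log units; beyond the scatter), so a second, smaller aryl group also stands far from the inactive end. Compound 1 stands at a limit of the assay, so this step is only a minimum: the limit of > 200000 nM in this assay, at which 1 of the 3 values shown sits.

Still open, from the compounds shown here alone, is how pyridin-3-yl, pyridin-4-yl or a saturated cyclohexyl group would fare on the amide nitrogen. Also open, going by these compounds, is whether a carboxylic acid on the ring would be tolerated.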